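This account rests on a few compounds, and the source may have more. Where it says the series, first, only, none or still open, it means among the compounds named here.

Measured compounds:
compound 1 `O=C(CCCCC1CCSS1)NCc1cn(CCCOc2ccc3cc(-c4ccccc4)c(=O)oc3c2)nn1` 33.9%
compound 2 `COc1ccc(-c2cc3ccc(OCCCn4cc(CNC(=O)CCCCC5CCSS5)nn4)cc3oc2=O)cc1` 42%
compound 3 `O=C(CCCCC1CCSS1)NCc1cn(CCCCCOc2ccc3cc(-c4ccccc4)c(=O)oc3c2)nn1` 35.5%

The study records these three in a functional assay on PC-12 cells (Rattus norvegicus) for cytotoxicity, read by MTT assay, with stated times of 3 h and 2 h, tested at 0.1 uM (a higher number here means a stronger effect of the compound at the concentration tested, a lower number a weaker effect), together with an unmeasured fourth, compound 4 `COc1ccc(-c2cc3ccc(OCCCCCn4cc(CNC(=O)CCCCC5CCSS5)nn4)cc3oc2=O)cc1`. Compound 2 differs from compound 1 by methoxy in place of hydrogen on an aromatic carbon, and the step measured is a number 8.1 percentage points higher from compound 1 to compound 2 (within the scatter). Compound 4 differs from compound 3 in the same way, (methoxy in place of hydrogen on an aromatic carbon), with the place described in identical words. How the core of compound 3 differs from that of compound 1 is not broken down here; their values in this assay lie within the usual scatter of each other. Given that one earlier step, compound 4 is expected to sit near compound 3, with a step of about a number 7.5 percentage points higher from compound 3 to compound 4 (within the scatter), because the same change gave a number 8.1 percentage points higher from compound 1 to compound 2 (within the scatter). Compound 4 is thus estimated at 43%, most likely between 32% and 55%.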

Compound 4, a percentage reported as activity, at one concentration (the size of the read-out at that concentration, not a potency): 34.5%
Beside the measured number, compound 4's estimate is 8.5 percentage points above it; low and high end bracket the measured number.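

In this assay, replacing phenyl with 4-methoxyphenyl gives a number 1 percentage points lower from compound 3 to compound 4 (within the scatter). Set beside the earlier step, the change shows no measurable dependence on the core: the same change on two cores in this assay, a number 8.1 percentage points higher (within the scatter) from compound 1 to compound 2 and a number 1 percentage points lower (within the scatter) from compound 3 to compound 4, 9.1 percentage points apart, within the scatter of two such steps. It does not show that methoxy has an effect of its own on either core, as each step lies within the scatter, and two cores cannot establish a rule for the series.

The compounds shown leave open how a hydroxy group, a chlorine atom or an amine on that same aromatic carbon would read in this assay. They also leave open whether a longer chain, or a shorter one, would alter the picture.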